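Working notes: vinyl in place of the chloroacetyl arm

The source may report more compounds than this note shows. Statements on the series, on what has been measured and on what is new or still open speak of the compounds shown alone.

In a functional assay on HT-29 cells (Homo sapiens) for antiproliferative activity, with a stated time of 48 h (a lower number here means a stronger inhibitor, a higher number a weaker inhibitor), compound 1 `CC(C)(C)c1ccc(CNC(=O)NC(=O)CCl)cc1` gives 7100 nM, the lowest of the two numbers shown, with compound 2 `CC(C)(C)c1ccc(NC(=O)CCl)cc1` next at 15000 nM. Compound 3 `CC(C)(C)c1ccc(NC(=O)CCCCl)cc1` gives > 100000 nM, which is a limit of this assay and not a number. Among the measured compounds shown here, the one single-change step measured, an at least 6.6-fold higher number from compound 2 to compound 3 (0.82 log units; beyond the scatter), shows that lengthening the halogenated chain weakens inhibition, ending at the limit of > 100000 nM in this assay, at which 1 of the 3 values shown sits. Compound 4 `C=CC(=O)NCc1ccc(C(C)(C)C)cc1` differs from compound 1 by vinyl in place of ((chloromethyl)carbonyl)amino on a carbonyl carbon. For the measured compounds named here, no measured step covers this change; the step from compound 2 to compound 3 only indicates that altering the chain on the carbonyl can cost potency. Compound 4 is therefore expected near 20000 nM, within 5000 nM to 80000 nM. The expected step of a 2.8-fold higher number from compound 1 to compound 4 (0.45 log units; beyond the scatter) is a weakening, with a fair chance of a limit only.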

Compound 4, half-maximal inhibitory concentration: > 100000 nM
Compound 4: only a limit was reported; the forecaster's own chance of this, stated with the estimate: 25%; middle value at least 5.0-fold (0.69 log units) from the limit.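

In this assay, vinyl in place of ((chloromethyl)carbonyl)amino on a carbonyl carbon gives an at least 14-fold higher number from compound 1 to compound 4 (1.14 log units; beyond the scatter), a large loss, whereas the earlier step concerned only the length of the halogenated chain. Compound 4 gives > 100000 nM, which is a limit of the assay and not a number. Removing the whole arm therefore ends at the same limit as lengthening the chain in compound 3: the limit of > 100000 nM in this assay, at which 2 of the 4 values shown sit.

As far as these compounds go, whether the chlorine itself or the rest of the arm carries the activity stays open. A methyl in place of the chloromethyl in compound 1 would separate the two.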